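The compounds below may be only part of what the source reports. "The series", "measured", "known", "first", "only" and "open" are said of these compounds alone.

Compound 1 `Oc1ccccc1-c1cc(-c2cccc(C(F)(F)F)c2)cc(-c2ccccc2O)n1` and compound 2 `Oc1ccccc1-c1cc(-c2ccc(C(F)(F)F)cc2)cc(-c2ccccc2O)n1` share a core. In a functional assay on HeLa cells (Homo sapiens) for inhibition (on this read-out lower numbers stand for stronger inhibition and higher numbers for weaker inhibition), compound 1 gives only a limit, > 50000 nM. Compound 2 likewise gives only a limit in this assay, > 50000 nM. The change between them, (4-(trifluoromethyl)phenyl in place of 3-(trifluoromethyl)phenyl on an aromatic carbon), therefore makes a step that the two limits leave unreadable from compound 1 to compound 2 because of the limit of > 50000 nM in this assay, at which 2 of the 3 values shown sit. Compound 3 `Oc1cccc(-c2cc(-c3cccc(C(F)(F)F)c3)cc(-c3ccccc3O)n2)c1` differs from compound 1 by 3-hydroxyphenyl in place of 2-hydroxyphenyl on an aromatic carbon, and in this assay compound 3 gives 19500 nM, which is an at least 2.5-fold lower number from compound 1 to compound 3 (0.40 log units; beyond the scatter). Compound 4 `Oc1cccc(-c2cc(-c3ccc(C(F)(F)F)cc3)cc(-c3ccccc3O)n2)c1` stands to compound 3 as compound 2 stands to compound 1: 4-(trifluoromethyl)phenyl in place of 3-(trifluoromethyl)phenyl on an aromatic carbon, the same kind of change, though here the place is meta to a 2-hydroxyphenyl group and meta to a 3-hydroxyphenyl group rather than meta to two 2-hydroxyphenyl groups. The earlier step has no readable size, so the step in this assay is expected to be a 1.5-fold higher number from compound 3 to compound 4 (0.19 log units; within the scatter), kept small, and rests only on compound 3 with its 19500 nM. Compound 4 is thus expected near 30000 nM, between 10000 nM and 80000 nM.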

Compound 4, half-maximal inhibitory concentration: > 50000 nM
Compound 4: no number, only a limit; the forecaster's own chance of this, stated with the estimate: 40%; middle value at least 1.6-fold (0.22 log units) from the limit.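

In this assay, 4-(trifluoromethyl)phenyl in place of 3-(trifluoromethyl)phenyl on the core of compound 3 makes an at least 2.5-fold higher number from compound 3 to compound 4 (0.40 log units; beyond the scatter). Compound 4 gives only a limit, > 50000 nM, so this step has a minimum size but no exact one. The same change on the core of compound 1 and the step between compound 2 and compound 4 cannot be read, so carry-over between the two cores is neither shown nor ruled out, because these pairs sit at a limit: the limit of > 50000 nM in this assay, at which 3 of the 4 values shown sit.

The compounds shown leave open how large the step from compound 3 to compound 4 really is. As far as these compounds go, how an amine or a carboxylic acid in place of trifluoromethyl on that phenyl ring would read in this assay also stays open.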